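Three limits and a methoxypyrrolidine replacement for an amide

This account rests on a few compounds, and the source may have more. Where it says the series, first, only, none or still open, it means among the compounds named here.

Compound 1 `CCN(CC)S(=O)(=O)c1ccc(S(=O)(=O)N2CCC[C@@H](C(=O)N[C@H]3CCOC3)C2)cc1` gives in a functional assay on MIA PaCa-2 cells (Homo sapiens) for inhibition, read by MTT assay, with a stated time of 3 days (on this read-out higher numbers stand for weaker inhibition and lower numbers for stronger inhibition), a value of > 10000 nM, which is a limit of the assay.
Compound 2 `CCN(CC)S(=O)(=O)c1ccc(S(=O)(=O)N2CCC[C@@H](C(=O)N3CCC(C(F)(F)F)CC3)C2)cc1` gives in this assay a value of > 10000 nM, also a limit.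
Compound 3 `CCN(CC)S(=O)(=O)c1ccc(S(=O)(=O)N2CCC[C@@H](C(=O)N[C@@H]3CCOC3)C2)cc1` gives in this assay a value of > 10000 nM, again a limit.

Compound 3 therefore stands at the same limit as the two other compounds, and no number separates any of them, as the limit of > 10000 nM in this assay, at which 3 of the 3 values shown sit, makes plain. The steps a step that the two limits leave unreadable from compound 1 to compound 2, a step that the two limits leave unreadable from compound 1 to compound 3 and a step that the two limits leave unreadable from compound 2 to compound 3 are all of unreadable size; even the fact that compounds 1 and 3 differ only in the configuration as drawn gives no readable difference.

Compound 4 `CCN(CC)S(=O)(=O)c1ccc(S(=O)(=O)N2CCC[C@@H](C(=O)N3CC[C@H](OC)C3)C2)cc1` differs from compound 3 by 3-methoxypyrrolidin-1-yl in place of (oxolan-3-yl)amino on a carbonyl carbon. All three measured steps bear on this change, since each swaps or alters the group on the carbonyl carbon, yet none yields a readable size. The expected step that the limit leaves unreadable from compound 3 to compound 4 is therefore most likely no readable change beyond the limit. Compound 4 is estimated at 15000 nM, with a range from 3000 nM to 60000 nM, and a further limit is the most probable outcome.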

Compound 4, half-maximal inhibitory concentration: > 10000 nM
Compound 4 ended at the assay's limit; the forecaster's own chance of this, stated with the estimate: 85%; the middle value does not contradict the limit.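

For the compounds shown here, no step from compound 1, compound 2 or compound 3 to compound 4 can be read, since all four compounds give a limit and not a number: the limit of > 10000 nM in this assay, at which 4 of the 4 values shown sit.

In this assay the compounds shown leave open how strongly any of the four inhibits, and whether any change on the carbonyl carbon alters that.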